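The source may hold more compounds than are shown below. What is called first, only, known or untested is meant among the compounds shown, and "the series" means these compounds.

Compounds measured in a functional assay on MDA-MB-231 cells (Homo sapiens) for cytotoxicity, read by MTT assay, with a stated time of 72 h, tested at 5 uM, in the absence of a further agent; on this read-out lower numbers stand for a stronger effect and higher numbers for a weaker effect at the one concentration tested:
compound 1, `CCCNC1=Nc2ccc(Cl)cc2C(C)(C)C1`; in this assay compound 1 gives 82.4%
compound 2, `CN(C)CCCNC1=Nc2ccc(Cl)cc2C(C)(C)C1`; in this assay compound 2 gives 38%

For the measured compounds named here, on these two numbers compound 2 stands lowest, with compound 1 the only neighbour, a number higher by the step of a number 44.4 percentage points lower from compound 1 to compound 2 (beyond the scatter). Compound 3, `CC1(C)CC(NCCCO)=Nc2ccc(Cl)cc21`, has not yet been measured in this assay. It differs from compound 2 in one place: hydroxy in place of dimethylamino on a saturated chain carbon, three bonds along the chain from an amine nitrogen.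

Going by the values given here, the one measured step that bears on this is a number 44.4 percentage points lower from compound 1 to compound 2 (beyond the scatter), which introduced the dimethylamino group and carried a large fall in the number. Compound 3 removes that group again, but replaces it with hydroxy rather than hydrogen, so only a partial return toward compound 1 is expected. A rise beyond the scatter, a number 27 percentage points higher from compound 2 to compound 3 (beyond the scatter), is therefore the estimate. Compound 3 is expected at 65%, within a range from 45% to 85%.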

Compound 3, a percentage reported as activity, at one concentration (the size of the read-out at that concentration, not a potency): 84.2%
Compound 3: middle estimate off by 19.2 percentage points, on the low side; measured number inside the range.
By their numbers in this assay, from the lowest: compound 2; then compounds 1 and 3 (each within the scatter of the next).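

In this assay, a step of a number 46.2 percentage points higher from compound 2 to compound 3 (beyond the scatter) shows that the lower number at this chain position does not survive the exchange of dimethylamino for hydroxy. With a number 1.8 percentage points higher from compound 1 to compound 3 (within the scatter) hydroxy and hydrogen are not told apart at this position, so among these three compounds the lower number stands with dimethylamino alone and not with just any group on this saturated chain carbon. Nothing available gives a reason for the difference between dimethylamino and hydroxy here.

Still open, from the compounds shown here alone, is whether the lower number extends to other amines at this place, such as a primary amine, pyrrolidine or morpholine, or depends on dimethylamino itself. Also open, going by these compounds, is how a longer or shorter chain carrying dimethylamino reads in this assay's terms, and whether a carboxylic acid behaves like hydroxy.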